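From chloro to methoxymethoxy in an antiproliferative series

The source may hold more compounds than are shown below. What is called first, only, known or untested is meant among the compounds shown, and "the series" means these compounds.

In a functional assay on MCF7 cells (Homo sapiens) for antiproliferative activity, read by MTT assay, with a stated time of 48 h (a higher number here means a weaker inhibitor, a lower number a stronger inhibitor), compound 2 `CC(C)=CCC[C@]1(C)/C=C/[C@@H](OC(=O)C=C(C)C)[C@](C)(O)/C=C/C(=O)/C(CCl)=C\C1` gives 610 nM, the lower of the two actual numbers available. The other number comes from compound 1 `C=C1/C=C/C(=O)/C(CO)=C\C[C@](C)(CCC=C(C)C)/C=C/[C@H]1OC(=O)C=C(C)C`, which gives 2750 nM, and this gap lies beyond the scatter. Compound 3 `CC(C)=CCC[C@]1(C)/C=C/[C@@H](OC(=O)C=C(C)C)[C@](C)(O)CCC(=O)/C(CO)=C\C1` gives no number, only a limit of the assay, > 40000 nM.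

Compound 4 `COCOC/C1=C/C[C@](C)(CCC=C(C)C)/C=C/[C@@H](OC(=O)C=C(C)C)[C@](C)(O)/C=C/C1=O` has yet to be measured. Compared with compound 2, it has methoxymethoxy in place of chloro on a saturated chain carbon bound to a double-bonded ring carbon. Within the data shown here, no pair of measured compounds differs in one place only, so the data offer no direct precedent for this change, and any forecast for this assay is necessarily loose. Among the measured compounds shown here, compound 2 holds the lowest number so far, and the nearest measured number belongs to compound 1, at 2750 nM, so the forecast leans towards that value. A move towards weaker inhibition, beyond the scatter, is therefore expected, with the estimate being a 4.9-fold higher number from compound 2 to compound 4 (0.69 log units; beyond the scatter). For compound 4 the estimated value is 3000 nM, with an expected range of 700 nM to 15000 nM.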

Compound 4, half-maximal inhibitory concentration: 3120 nM
For compound 4 the middle estimate is 1.0-fold (0.02 log units) below the measured one; the range from low to high includes it.
By their numbers in this assay, from the lowest: compound 2; then compounds 1 and 4 (each within the scatter of the next). At a limit, above all of these: compound 3.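

In this assay, among these compounds, the change of chloro to methoxymethoxy on a saturated chain carbon bound to a double-bonded ring carbon gives a 5.1-fold higher number from compound 2 to compound 4 (0.71 log units; beyond the scatter) and is the first step that can be read at one place alone, showing that the activity of this core responds to what this position carries. The response is not a collapse, since compound 4 still gives an actual number of 3120 nM and not a limit of the assay, so a group of 4 heavy atoms with 2 hydrogen-bond acceptors can stand where a single chlorine stood and measurable activity remains. Nothing shown here accounts for the size of this step, and the one limit in the set has no bearing on it.

This single pair leaves open whether the step reflects chloro leaving or methoxymethoxy entering, as only these two groups are compared at this position on an otherwise unchanged core. A bromo group, an amine or a simple methoxy group at the same place on the core of compound 2 would help to separate those two readings.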